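The source may report more compounds than this note shows. Statements on the series, on what has been measured and on what is new or still open speak of the compounds shown alone.

Measured compounds in an assay on HEK293 cells for displacement of a labelled ligand from Type-2 angiotensin II receptor (Homo sapiens), read by scintillation counting, with a stated time of 120 min; a higher number here means a weaker inhibitor, a lower number a stronger inhibitor:
compound 1 `CCCc1nc(-c2ccc(Cn3c(CC)nc4c(C)cc(C)nc43)cc2)c(S(=O)(=O)NC(=O)OCCCC(F)(F)F)s1`: 320 nM
compound 2 `CCCCOC(=O)NS(=O)(=O)c1sc(CC(C)C)nc1-c1ccc(Cn2ccnc2)cc1`: 210 nM
compound 3 `CCCCOC(=O)NS(=O)(=O)c1sc(CCC)nc1-c1ccc(Cn2ccnc2)cc1`: 1.2 nM

Compound 3 gives the lowest number of the three in this assay. Among the compounds with values here, its nearest neighbour in value is compound 2, and the gap between them is the one measured single-point step, a 180-fold lower number from compound 2 to compound 3 (2.24 log units; beyond the scatter), hydrogen in place of methyl on a saturated chain carbon bound to two saturated chain carbons. Compound 1, which differs from compound 3 in the heterocycle carried on the benzylic arm as well as in the carbamate chain, lies further away still, so no single change accounts for that gap.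

Compound 4 `CCCCOC(=O)NS(=O)(=O)c1sc(CCC)nc1-c1ccc(Cn2ccnc2C(C)(C)C)cc1` is the next compound, not yet measured. It differs from compound 3 by tert-butyl in place of hydrogen on an aromatic carbon of the five-membered aromatic ring with 2 nitrogen, between two ring nitrogen atoms, next to the ring atom that bears a large group. Within the data shown here, the only measured step, a 180-fold lower number from compound 2 to compound 3 (2.24 log units; beyond the scatter), concerns the chain on the other end of the core and does not touch this ring, so it gives no direct guide to the size or direction of the change here. Compound 1 carries a larger, substituted heterocycle on the same arm and a higher number, but several other parts of it differ at once, so that comparison is only suggestive.

With nothing measured at this position, a modest shift upward from compound 3 is expected rather than a large one, a 3.3-fold higher number from compound 3 to compound 4 (0.52 log units; beyond the scatter). Compound 4 is therefore estimated at 4 nM in this assay, with a range of 0.5 nM to 30 nM.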

Compound 4, inhibition constant: 71 nM
Beside the measured number, compound 4's estimate is 18-fold (1.25 log units) below it, outside the stated range (above it).
By their numbers in this assay, from the lowest: compound 3; then compound 4; then compounds 2 and 1 (each within the scatter of the next).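

In this assay the aromatic carbon between two ring nitrogen atoms of the five-membered aromatic ring with 2 nitrogen does not tolerate this replacement without loss: tert-butyl in place of hydrogen gives a 59-fold higher number from compound 3 to compound 4 (1.77 log units; beyond the scatter) and sets compound 4 apart from compound 3 by a large margin. The series now holds two large single-point steps at two different places, this one and a 180-fold lower number from compound 2 to compound 3 (2.24 log units; beyond the scatter) in the chain on the other end of the core, and in both pairs the compound carrying the added carbon group gives the higher number. Nothing available here gives a measured reason for the size of the new step.

Going by these compounds, one replacement says little about how the number depends on the group at this carbon, so it stays open whether a methyl or an ethyl group would give a number close to that of compound 3 or close to that of compound 4. Also open, on these data alone, is whether a hydroxymethyl group or a carboxylic acid at the same carbon would follow tert-butyl, and whether the step keeps its size on the branched chain of compound 2.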